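The compounds below may be only part of what the source reports. "The series", "measured", "known", "first", "only" and "open" are said of these compounds alone.

Working notes on the series.

Within the data shown here, compound 3 `CCOC(=O)C1=C(N/N=C(/C(=O)Br)c2ccc(Br)cc2)Nc2[nH]nc(C)c2C1c1ccc(N(C)C)cc1` is second highest of the three numbers so far in a functional assay on HeLa cells (Homo sapiens) for inhibition, read by MTT assay, with a stated time of 48 h; a lower number here means a stronger inhibitor, a higher number a weaker inhibitor. The nearest is compound 2 `CCOC(=O)C1=C(N/N=C(\c2ccc([N+](=O)[O-])cc2)N2CCN(c3ccc(F)cc3)CC2)Nc2[nH]nc(C)c2C1c1ccc(N(C)C)cc1`, which in this assay gives 87000 nM, a gap within the scatter against compound 3 at 68500 nM. Among the measured compounds shown here, the furthest is compound 1 `CCOC(=O)C1=C(NN=C(C(C)=O)C(C)=O)Nc2[nH]nc(C)c2C1c1ccc(N(C)C)cc1`, which in this assay gives 17000 nM; the one step recorded, a 4.0-fold higher number from compound 1 to compound 3 (0.61 log units; beyond the scatter), is the only change that bears on the present question, since it also exchanged the group on the amine nitrogen.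

Compound 4 `CCOC(=O)C1=C(N/C=N/c2ccccn2)Nc2[nH]nc(C)c2C1c1ccc(N(C)C)cc1` is still to be measured. It differs from compound 3 by a group of 8 heavy atoms (6 carbon, 2 nitrogen; one six-membered aromatic ring with 1 hetero atom) in place of a group of 12 heavy atoms (8 carbon, 1 nitrogen, 1 oxygen, 2 bromine; one six-membered aromatic ring of carbon only), on an amine nitrogen. For the measured compounds named here, the series gives no direct precedent for the entering group; what it shows is that an exchange at this nitrogen has moved the number by a modest amount, and that the smaller substituent of compound 1 sat at the lower end. On that basis a modest downward move is expected for compound 4, a 2.3-fold lower number from compound 3 to compound 4 (0.36 log units; beyond the scatter), with wide uncertainty. Compound 4 is therefore estimated in this assay at 30000 nM, within a range from 7000 nM to 130000 nM.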

Compound 4, half-maximal inhibitory concentration: 29200 nM
The estimate for compound 4 lay 1.0-fold (0.01 log units) above the measured number; low and high end bracket the measured number.
By their numbers in this assay, from the lowest: compounds 1 and 4 (each within the scatter of the next); then compounds 3 and 2 (each within the scatter of the next).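

At the amine nitrogen, the ring-bearing groups are now seen to differ from each other: in this assay, the step of a 2.3-fold lower number from compound 3 to compound 4 (0.37 log units; beyond the scatter) comes with one six-membered aromatic ring with 1 hetero atom in place of one six-membered aromatic ring of carbon only, and with 8 heavy atoms in place of 12 heavy atoms. The ring-free group of compound 1 and the ring-bearing group of compound 4 are not separated, as the step of a 1.7-fold higher number from compound 1 to compound 4 (0.23 log units; within the scatter) shows, so among these compounds the presence of a ring does not alone set the number. Nothing measured here explains either step.

Going by these compounds, whether an entering group bearing a primary amine or a carboxylic acid would give a number outside those seen remains open. So does whether any group at this nitrogen can give a number well below that of compound 1 and compound 4.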